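Removing the 3-Iodobenzyl Group from the Amine of Compound 2

The source may hold more compounds than are shown below. What is called first, only, known or untested is meant among the compounds shown, and "the series" means these compounds.

Going by the values given here, compound 2 `CCCCC#Cc1nc(NCc2cccc(I)c2)c2ncn([C@H]3[C@H](O)[C@H](O)[C@@H]4C[C@@H]43)c2n1` holds the lowest number of the three compounds measured so far in an assay on RBL-2H3 cells for displacement of a labelled ligand from adenosine receptor A3 (Rattus norvegicus), with a stated time of 60 min; a lower number here means a stronger inhibitor, a higher number a weaker inhibitor: in this assay compound 2 gives 26 nM. Its nearest neighbour is compound 1 `CCCCC#Cc1nc(NCc2cccc(Br)c2)c2ncn([C@H]3[C@H](O)[C@H](O)[C@@H]4C[C@@H]43)c2n1`, which in this assay gives 59 nM; the step of a 2.3-fold lower number from compound 1 to compound 2 (0.36 log units; beyond the scatter) comes from iodo in place of bromo on the aromatic carbon. Compound 3 `CCCCC#Cc1nc(NC)c2ncn([C@H]3[C@H](O)[C@H](O)[C@@H]4C[C@@H]43)c2n1` stands furthest away, giving 231 nM in this assay; the step of an 8.9-fold higher number from compound 2 to compound 3 (0.95 log units; beyond the scatter) and the parallel step a 3.9-fold higher number from compound 1 to compound 3 (0.59 log units; beyond the scatter) both describe the loss of the halogenated phenyl ring from the saturated chain carbon bound to the ring nitrogen.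

Compound 4 `CCCCC#Cc1nc(N)c2ncn([C@H]3[C@H](O)[C@H](O)[C@@H]4C[C@@H]43)c2n1` has not yet been measured. It differs from compound 2 by hydrogen in place of 3-iodobenzyl on a nitrogen on an aromatic ring. Among the compounds with values here, the steps that bear on this change are those from compound 1 and compound 2 to compound 3, which removed the aryl ring while the chain carbon on the nitrogen stayed; here the whole 3-iodobenzyl group is taken off. The same direction is therefore expected, a higher number, of a size at least as large as an 8.9-fold higher number from compound 2 to compound 3 (0.95 log units; beyond the scatter). The estimate for compound 4 in this assay is 600 nM, with a range from 150 nM to 2500 nM. This corresponds to an expected step of a 23-fold higher number from compound 2 to compound 4 (1.36 log units; beyond the scatter).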

Compound 4, inhibition constant: 65 nM
For compound 4 the middle estimate is 9.2-fold (0.97 log units) above the measured one; measured number below the stated range.
By their numbers in this assay, from the lowest: compound 2; then compounds 1 and 4 (each within the scatter of the next); then compound 3.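

In this assay, the number does not climb steadily as the group on the nitrogen shrinks: a 3.6-fold lower number from compound 3 to compound 4 (0.55 log units; beyond the scatter) shows that hydrogen on the nitrogen on an aromatic ring gives a stronger inhibitor than methyl, so compound 3, not the bare amine, stands apart from the others. Taking off the whole 3-iodobenzyl group gives only a 2.5-fold higher number from compound 2 to compound 4 (0.40 log units; beyond the scatter), while a 1.1-fold higher number from compound 1 to compound 4 (0.04 log units; within the scatter) leaves hydrogen and 3-bromobenzyl indistinguishable at this position, so among the benzyl compounds shown only the iodo one keeps an edge over the unsubstituted amino group. Nothing available here bears on why methyl and hydrogen differ in this way.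

The compounds shown leave open how the number behaves between methyl and 3-halobenzyl, which an ethyl group, a propyl group or an unsubstituted benzyl group on the same nitrogen would help to trace. They also leave open whether a chloro group on the benzyl ring would fall with the bromo compound or whether hydrogen and methyl would keep this order with a shorter alkyne chain on the core.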